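A few compounds are considered here, and "the series" means these few. Any claim that something is new, unique, unknown or untested is made for them only; others in the source may bear on it.

Measured compounds:
- compound 1, `O=[N+]([O-])c1ccc(NN=C(c2ccccc2)c2ccccc2)c([N+](=O)[O-])c1` — a functional assay on cells (Melanoma tumor cell line, Homo sapiens) for cytotoxicity; on this read-out lower numbers stand for stronger inhibition and higher numbers for weaker inhibition: > 5 ug/mL
- compound 2, `O=[N+]([O-])c1ccc(N/N=C(\c2ccccc2)c2ccc(O)cc2)c([N+](=O)[O-])c1` — this assay: 5 ug/mL

Compound 1 gives > 5 ug/mL in this assay, which is a limit of the assay and not a number. For the measured compounds named here, compound 2 gives 5 ug/mL in this assay, which is the only number among the values shown. The further value shown, that of compound 1, is a limit. The step of a number no higher from compound 1 to compound 2 (the limit leaves the size open) brought hydroxy in place of hydrogen on an aromatic carbon, and its size cannot be read because of the limit of > 5 ug/mL in this assay, at which 1 of the 2 values shown sits.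

Compound 3 `O=[N+]([O-])c1ccc(N/N=C(\c2ccccc2)c2ccc(O)cc2O)c([N+](=O)[O-])c1` has not yet been measured in this assay. It differs from compound 2 in one place: hydroxy in place of hydrogen on an aromatic carbon. Going by the values given here, the only measured step that bears on this change is the one from compound 1 to compound 2, which is of the same kind, hydroxy in place of hydrogen on an aromatic carbon, but whose size is left open by the limit. No direction can therefore be drawn from it, and no step beyond the usual scatter is expected. Compound 3 is expected to give 5 ug/mL in this assay, within 2 ug/mL to 12 ug/mL. This estimate means a step of no change at the digits printed from compound 2 to compound 3 (within the scatter).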

Compound 3, half-maximal inhibitory concentration: 0.5 ug/mL
Estimate against measurement, compound 3: 10-fold (1.00 log units) above; the whole stated range lies above it.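

In this assay, hydroxy in place of hydrogen on an aromatic carbon, ortho to a large group and meta to a hydroxy group, gives a 10-fold lower number from compound 2 to compound 3 (1.00 log units; beyond the scatter). For the compounds shown here, the change is 4-hydroxyphenyl to 2,4-dihydroxyphenyl, and this is the first step of its kind with a size that can be read. Going by these compounds alone, the one earlier hydroxy step, which starts from compound 1, cannot be read, because compound 1 sits at a limit of the assay: the limit of > 5 ug/mL in this assay, at which 1 of the 3 values shown sits. So the compounds now show that this position on the ring can carry a change beyond the scatter, though that rests on a single pair in which a hydroxy group is already present on the same ring.

The compounds shown leave open whether a methoxy group or an amine at this position would give a number like that of compound 3, which would tell whether the step is tied to hydroxy itself. They also leave open whether hydroxy at this position would give a step of similar size on a ring without the other hydroxy group.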